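The source may report more compounds than this note shows. Statements on the series, on what has been measured and on what is new or still open speak of the compounds shown alone.

Measured compounds in an ADME assay on Huh-5-2 cells (Homo sapiens) for cytotoxicity, read by WST assay, with a stated time of 3 days; a higher number here means that more compound is tolerated, a lower number that less compound is tolerated: compound 1 `Cc1ccccc1COc1c(-c2ccccc2)oc2cc(O)cc(O)c2c1=O` gives 55000 nM; compound 2 `COc1ccccc1COc1c(-c2ccccc2)oc2cc(O)cc(O)c2c1=O` gives 53000 nM; compound 3 `Cc1cccc(COc2c(-c3ccccc3)oc3cc(O)cc(O)c3c2=O)c1` gives 29000 nM.

Compound 3 has the lowest number of the three, but its gaps to compound 2 and compound 1 are within the scatter, so the three sit together. The steps of a 1.9-fold lower number from compound 1 to compound 3 (0.28 log units; within the scatter) and a 1.8-fold lower number from compound 2 to compound 3 (0.26 log units; within the scatter) move the benzyl substituent around the ring without a change beyond the scatter, and a 1.0-fold lower number from compound 1 to compound 2 (0.02 log units; within the scatter) shows the same for a methyl-to-methoxy swap.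

Compound 4 `Cc1ccc(COc2c(-c3ccccc3)oc3cc(O)cc(O)c3c2=O)cc1` differs from compound 3 only by 4-methylphenyl in place of 3-methylphenyl on a saturated chain carbon bound to an oxygen on an aromatic ring. Within the data shown here, nothing measured so far separates such positional shifts beyond the scatter, so no step beyond the scatter is expected: the estimated change is a 1.3-fold higher number from compound 3 to compound 4 (0.12 log units; within the scatter). For compound 4 the expected value in this assay is 38000 nM, within 18000 nM to 80000 nM.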

Compound 4, half-maximal cytotoxic concentration: 40000 nM
Estimate against measurement, compound 4: 1.1-fold (0.02 log units) below; the range from low to high includes it.
By their numbers in this assay, from the lowest: compounds 3, 4, 2 and 1 (each within the scatter of the next).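

With 4-methylphenyl, all three methyl placements on the benzyl group have now been read in this assay, and the new placement stays within the scatter of the other two (a 1.4-fold higher number from compound 3 to compound 4 (0.14 log units; within the scatter); a 1.4-fold lower number from compound 1 to compound 4 (0.14 log units; within the scatter)). The 4-methylphenyl group also stays within the scatter of 2-methoxyphenyl (a 1.3-fold lower number from compound 2 to compound 4 (0.12 log units; within the scatter)). No measurement available here explains this flat response.

As far as these compounds go, whether an amine or a carboxylic acid on this phenyl ring, or a longer chain in place of the methyl, would move the number beyond the scatter remains open.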